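From 3,4-dihydroxyphenoxy to benzyloxy in compound 3

The source may report more compounds than this note shows. Statements on the series, on what has been measured and on what is new or still open speak of the compounds shown alone.

Measured in a functional assay on RS4-11 cells (Homo sapiens) for inhibition, read by CCK-8 assay, with a stated time of 48 h (a higher number here means a weaker inhibitor, a lower number a stronger inhibitor), so far:
Compound 1 `O=C(NCCNS(=O)(=O)c1ccc(-c2ccccc2Oc2ccc(O)c(O)c2)s1)Nc1cc(Cl)cc(Cl)c1` gives 4500 nM
Compound 2 `O=S(=O)(NCCNC(=S)Nc1cc(C(F)(F)F)cc(C(F)(F)F)c1)c1ccc(-c2ccccc2O[C@H]2CC[C@@H](O)CC2)s1` gives 6300 nM

Among the compounds with values here, compound 1 is one of only two measured compounds, and its value lies within the usual scatter of the value for compound 2, so the pair shows no order. Within the data shown here, no two measured compounds differ in a single place, which leaves no direct guide to the next change.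

Compound 3 `O=C(NCCNS(=O)(=O)c1ccc(-c2ccccc2OCc2ccccc2)s1)Nc1cc(Cl)cc(Cl)c1` departs from compound 1 in one place benzyl in place of 3,4-dihydroxyphenyl on an oxygen on an aromatic ring and carries benzyl in place of 3,4-dihydroxyphenyl on an oxygen on an aromatic ring. With so little to go on, no change beyond the scatter is expected in this assay and neither direction is favoured, although the data cannot rule out a larger one. The estimate amounts to an expected 1.1-fold higher number from compound 1 to compound 3 (0.05 log units; within the scatter) and no more. Compound 3 is estimated at 5000 nM with an expected range from 1800 nM to 14000 nM and its measurement follows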

Compound 3, half-maximal inhibitory concentration: > 20000 nM
Compound 3 was reported as a limit; the forecaster's own chance of this, stated with the estimate: 10%; middle value at least 4.0-fold (0.60 log units) from the limit.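

In this assay, within the data shown here, this is the first step that can be read at this place, on an oxygen on an aromatic ring: benzyl in place of 3,4-dihydroxyphenyl gives an at least 4.4-fold higher number from compound 1 to compound 3 (0.64 log units; beyond the scatter). The group on this oxygen therefore cannot be exchanged freely in this assay, something the earlier pair, which differs in more than one place, could not show. For compound 3 the value > 20000 nM is a limit and not a number, so the step has only a lower bound: the limit of > 20000 nM in this assay, at which 1 of the 3 values shown sits.

The compounds shown leave open whether the loss of the hydroxyl groups or the move from a phenoxy to a benzyloxy link accounts for the step, since this change alters both at once. Also open, from the compounds shown here alone, is how a plain phenoxy, a 3,4-dihydroxybenzyl group, or an amine or carboxylic acid on the ring would read at this place.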